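Chloro for trifluoromethyl on a pyrazole urea series

The source may report more compounds than this note shows. Statements on the series, on what has been measured and on what is new or still open speak of the compounds shown alone.

Compound 1: `O=C(Nc1cccc(-n2cc(-c3ccncc3)c(-c3cc(O)cc(Cl)c3)n2)c1)Nc1ccc(Cl)c(Cl)c1` — 106%
Compound 2: `COc1cc(Cl)cc(-c2nn(-c3cccc(NC(=O)Nc4ccc(Cl)c(C(F)(F)F)c4)c3)cc2-c2ccncc2)c1` — 98%

Of the compounds shown here, two have been measured in a functional assay on T47D cells (Homo sapiens) for inhibition, read by sulforhodamine B assay, with a stated time of 48 h, tested at 0.01 uM; a lower number here means a stronger effect, a higher number a weaker effect of the compound at the concentration tested. Within the data shown here, in that assay compound 2 gives 98%, and compound 1 gives 106%, the only other number, which sits within the usual scatter of the figure for compound 2. With two values so close, nothing separates them, and no step beyond the scatter has been recorded among the measured compounds.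

Compound 3, `COc1cc(Cl)cc(-c2nn(-c3cccc(NC(=O)Nc4ccc(Cl)c(Cl)c4)c3)cc2-c2ccncc2)c1`, has not been measured. It is derived from compound 2 by one change: chloro in place of trifluoromethyl on an aromatic carbon. Among the measured compounds shown here, since the only two numbers seen so far are within the scatter of each other, the step from compound 2 to compound 3 is expected to be a number 2 percentage points higher from compound 2 to compound 3 (within the scatter), that is, no step beyond the scatter in either direction. The value expected for compound 3 is therefore 100%, in a range from 85% to 115%.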

Compound 3, a percentage reported as activity, at one concentration (the size of the read-out at that concentration, not a potency): 94%
Beside the measured number, compound 3's estimate is 6 percentage points above it; low and high end bracket the measured number.
By their numbers in this assay, from the lowest: compounds 3, 2 and 1 (each within the scatter of the next, the first and the last beyond it).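

In this assay, chloro in place of trifluoromethyl on an aromatic carbon, which turns 4-chloro-3-(trifluoromethyl)phenyl into 3,4-dichlorophenyl, gives a number 4 percentage points lower from compound 2 to compound 3 (within the scatter), so this change at this position has no readable effect at the one concentration tested. Among these compounds, compound 3 also provides the first step beyond the scatter in the set: methyl in place of hydrogen on an oxygen on an aromatic ring gives a number 12 percentage points lower from compound 1 to compound 3 (beyond the scatter), a modest step. No measurement here bears on the reason for either step.

The compounds shown leave open whether a nitrile at the place of the trifluoromethyl, or an amine at the place of the methylated oxygen, would move the number beyond the scatter. They also leave open whether these steps would hold at other concentrations, since a single-concentration read-out is not a potency.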